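Hydroxy Added Ortho to Methoxy: the Expected Change

The source may report more compounds than this note shows. Statements on the series, on what has been measured and on what is new or still open speak of the compounds shown alone.

Measured so far:
Compound 1 `Nc1nc(-c2ccccn2)nn1-c1ncnc2ccccc12` gives only a limit, > 40000 nM, in an assay on MCF7 cells for inhibition of Serine-protein kinase ATM (Homo sapiens), read by immunofluorescence, with a stated time of 1 h; on this read-out lower numbers stand for stronger inhibition and higher numbers for weaker inhibition.
Compound 2 `COc1ccc2ncnc(-n3nc(-c4ccccn4)nc3N)c2c1` gives 16900 nM in this assay.

Among the measured compounds shown here, compound 2 holds the only actual number in this assay; the other result is a limit, (the limit of > 40000 nM in this assay, at which 1 of the 2 values shown sits). For the measured compounds named here, the one measured step, an at least 2.3-fold lower number from compound 1 to compound 2 (0.37 log units; beyond the scatter), is the sole guide to how a small oxygen substituent on the fused ring system of the shared core affects this assay.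

Compound 3 `COc1cc2c(-n3nc(-c4ccccn4)nc3N)ncnc2cc1O` differs from compound 2 by hydroxy in place of hydrogen on an aromatic carbon. This is a second oxygen substituent of the same kind, placed on the same ring. The step from compound 1 to compound 2 lies beyond the scatter, so a further change of roughly that order, toward a lower number, is a reasonable expectation, though a result within the scatter of compound 2 cannot be excluded from one step alone. For compound 3 the expected step in this assay is therefore a 1.9-fold lower number from compound 2 to compound 3 (0.27 log units; within the scatter). Compound 3 is estimated to give 9000 nM, in the range 3000 nM to 30000 nM.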

Compound 3, half-maximal inhibitory concentration: > 40000 nM
Compound 3 gave a limit, no number (the forecaster's own chance of this, stated with the estimate: 10%); at least 4.4-fold (0.64 log units) between middle value and limit.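

Hydroxy in place of hydrogen on this aromatic carbon, ortho to a methoxy group, runs against the only earlier step. In this assay the change gives an at least 2.3-fold higher number from compound 2 to compound 3 (0.37 log units; beyond the scatter), whereas the methoxy change had given an at least 2.3-fold lower number from compound 1 to compound 2 (0.37 log units; beyond the scatter). A second oxygen substituent on this ring therefore does not repeat the result of the first, and one oxygen substituent cannot serve as a guide to another on this ring in this assay. Compound 3 gives a limit and not a number, so the full size of the step stays unknown, and compound 2 remains the only compound shown with an actual number: the limit of > 40000 nM in this assay, at which 2 of the 3 values shown sit.

The compounds shown leave open whether the higher number belongs to hydroxy as such or to hydroxy placed ortho to a methoxy group, as this group appears in one setting only. They also leave open whether an amine or a longer chain ending in an ether oxygen on this same aromatic carbon would stay near compound 2 in this assay or would also reach the limit.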